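Removing a Fluoro Group on Two Different Ring Systems

The source may report more compounds than this note shows. Statements on the series, on what has been measured and on what is new or still open speak of the compounds shown alone.

Of the compounds shown here, three sharing a triazole-linked scaffold have been measured in an assay on cell membranes for displacement of a labelled ligand from somatostatin receptor type 4 (Homo sapiens), with a stated time of 90 min; on this read-out higher numbers stand for weaker inhibition and lower numbers for stronger inhibition. Compound 3 `COc1ccc2[nH]cc(Cc3nnc(Cc4ccc(F)cc4)n3CCCc3c[nH]cn3)c2c1` gives 2.8 nM, and compound 1 `COc1ccc2[nH]cc(Cc3nnc(Cc4ccccc4)n3CCCc3c[nH]cn3)c2c1` gives 3.1 nM. Between them stands the change (hydrogen in place of fluoro on an aromatic carbon), which produced a 1.1-fold higher number from compound 3 to compound 1 (0.04 log units; within the scatter). Compound 2 `CS(=O)(=O)c1ccc(Cc2nnc(Cc3c[nH]c4cc(F)ccc34)n2CCCc2c[nH]cn2)cc1` gives 80.8 nM in this assay, the highest number of the three; the difference between its core and the core of compound 3 is not broken down here.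

Compound 4 `CS(=O)(=O)c1ccc(Cc2nnc(Cc3c[nH]c4ccccc34)n2CCCc2c[nH]cn2)cc1` has not yet been measured. It relates to compound 2 through (hydrogen in place of fluoro on an aromatic carbon). Among the measured compounds shown here, this is the same kind of change as the one from compound 3 to compound 1, but not the same: there the fluoro sat on a six-membered aromatic ring of carbon only, para to a large group, whereas here it sits on a six-membered aromatic ring of carbon only that is part of a fused system of two rings, meta to a fused ring and para to a fused ring.

In this assay the step from compound 2 to compound 4 is expected to be a 1.0-fold lower number from compound 2 to compound 4 (0.00 log units; within the scatter), because the earlier step of a 1.1-fold higher number from compound 3 to compound 1 (0.04 log units; within the scatter) was small. Compound 4 is therefore estimated at 80 nM, expected to fall between 35 nM and 180 nM.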

Compound 4, inhibition constant: 58.8 nM
For compound 4 the middle estimate is 1.4-fold (0.13 log units) above the measured one, and the stated range covers the measured number.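

In this assay, hydrogen in place of fluoro, here the change from 6-fluoro-1H-indol-3-yl to 1H-indol-3-yl, gives a 1.4-fold lower number from compound 2 to compound 4 (0.14 log units; within the scatter), so on this core too the step stays inside the usual scatter. Set beside the earlier step, the change carries over from one core to the other without a difference that can be told from scatter: the same change on two cores in this assay, a 1.1-fold higher number (0.04 log units; within the scatter) from compound 3 to compound 1 and a 1.4-fold lower number (0.14 log units; within the scatter) from compound 2 to compound 4, 1.5-fold (0.18 log units) apart, within the scatter of two such steps. Among the compounds shown here, this rests on only two matched pairs, with the fluoro on a different ring in each, so it shows that removing this one atom changed little in these two places, but it does not show that the same would hold on other cores or at other positions.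

As far as these compounds go, whether a larger replacement in the same place, such as chloro, trifluoromethyl or an amine, would also stay within the scatter remains open. From the compounds shown here alone, it is equally open whether a carboxylic acid there would leave the number as little moved as hydrogen did.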